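The source may report more compounds than this note shows. Statements on the series, on what has been measured and on what is new or still open speak of the compounds shown alone.

Compound 1: `O=C(NC[C@@H](O)C(=O)O)c1ccc(CN(C(=O)Nc2cccc(Br)c2)c2ccc(C3CCCCC3)cc2)cc1`, 8 nM in an in vitro assay on BHK cells for binding affinity to Glucagon receptor (Homo sapiens); a lower number here means a stronger inhibitor, a higher number a weaker inhibitor.
Compound 2: `O=C(NC[C@@H](O)C(=O)O)c1ccc(CN(C(=O)Nc2cc(Br)cc(C(F)(F)F)c2)c2ccc(C3=CCCCC3)cc2)cc1`, 7 nM in this assay.

Compound 2 and compound 1 sit within the scatter of each other in this assay, so neither can be set apart. Compound 3, `O=C(NC[C@@H](O)C(=O)O)c1ccc(CN(C(=O)Nc2ccccc2)c2ccc(C3=CCCCC3)cc2)cc1`, has not been measured. It differs from compound 2 by phenyl in place of 3-bromo-5-(trifluoromethyl)phenyl on an amide-type nitrogen. For the measured compounds named here, no measured pair shows this change, so its effect can only be guessed. Compound 3 is expected to give a somewhat higher number than compound 2, a step of a 4.3-fold higher number from compound 2 to compound 3 (0.63 log units; beyond the scatter), beyond the scatter but modest. Compound 3 is estimated at 30 nM, within 8 nM to 120 nM.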

Compound 3, half-maximal inhibitory concentration: 166 nM
Compound 3: the middle estimate sits 5.5-fold (0.74 log units) below what was measured; measured number outside the range, above it.
By their numbers in this assay, from the lowest: compounds 2 and 1 (each within the scatter of the next); then compound 3.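

On the amide-type nitrogen, phenyl in place of 3-bromo-5-(trifluoromethyl)phenyl gives a large loss in this assay, a 24-fold higher number from compound 2 to compound 3 (1.38 log units; beyond the scatter). For the compounds shown here, the earlier compounds offered no step at this place, so this is the first sign that the number depends strongly on what this ring carries. Nothing available explains the size of this step.

Left open is whether bromine or trifluoromethyl alone would hold the number with the rest of compound 2 unchanged. Also open, from the compounds shown here alone, is whether another group on this ring, such as chlorine or a nitrile, would serve equally well.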